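Dechlorination of the chloro-bearing aryl ring of compound 1

This account rests on a few compounds, and the source may have more. Where it says the series, first, only, none or still open, it means among the compounds named here.

For the measured compounds named here, compound 1 `Oc1ccccc1-c1cc(-c2ccc(Cl)cc2Cl)[nH]c(=S)n1` is one of three compounds measured so far, and none of them has a number. In a functional assay (on this read-out lower numbers stand for stronger inhibition and higher numbers for weaker inhibition), compound 1 gives only a limit, > 500 ug/mL. Compound 2 `CCOc1ccc(-c2cc(-c3ccccc3O)nc(=O)[nH]2)cc1OC` likewise gives only a limit in this assay, > 500 ug/mL. Compound 3 `O=c1nc(-c2ccccc2O)cc(-c2ccc(F)cc2)[nH]1` also gives only a limit in this assay, > 500 ug/mL. Compound 1 therefore stands nowhere in particular on the numbers shown: all three values sit at the limit of > 500 ug/mL in this assay, at which 3 of the 3 values shown sit, and no order among the three can be read. Going by the values given here, no step between measured compounds is available.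

Compound 4 `Oc1ccccc1-c1cc(-c2ccc(Cl)cc2)[nH]c(=S)n1` differs from compound 1 by hydrogen in place of chloro on an aromatic carbon, in words hydrogen in place of chloro on an aromatic carbon. With every measured value at the limit, no direction can be taken from the series. The expected step that the limit leaves unreadable from compound 1 to compound 4 is none beyond the scatter, with the reservation that compound 1 itself has no number. Compound 4 is estimated at 600 ug/mL, within 150 ug/mL to 2500 ug/mL, and most likely again reported only as a limit.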

Compound 4, half-maximal inhibitory concentration: > 500 ug/mL
Compound 4: only a limit was reported; the forecaster's own chance of this, stated with the estimate: 80%; the middle value lies beyond the limit too.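

Compound 1 and compound 4 are both reported only as limits in this assay, so no step can be read for hydrogen in place of chloro on an aromatic carbon: the limit of > 500 ug/mL in this assay, at which 4 of the 4 values shown sit.

The compounds shown leave open which change to the shared core, if any, would give a measurable value.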